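Amide to urea on the weakest of three pyrazoles

The source may report more compounds than this note shows. Statements on the series, on what has been measured and on what is new or still open speak of the compounds shown alone.

Three compounds share one core and differ only in the group on the carbonyl carbon. Compound 1 `COc1cc(-c2nn(-c3cccc(NC(=O)c4cccc(C(F)(F)F)c4)c3)cc2-c2ccncc2)ccc1Cl` gives 3150 nM in a functional assay on RXF 393 cells (Homo sapiens) for inhibition, read by sulforhodamine B assay, with a stated time of 48 h; a higher number here means a weaker inhibitor of growth, a lower number a stronger inhibitor of growth; compound 2 `COc1cc(-c2nn(-c3cccc(NC(=O)Nc4ccc(Cl)c(Cl)c4)c3)cc2-c2ccncc2)ccc1Cl` gives 2440 nM; compound 3 `COc1cc(-c2nn(-c3cccc(NC(=O)c4ccc(Cl)c(C(F)(F)F)c4)c3)cc2-c2ccncc2)ccc1Cl` gives 18700 nM, the highest of the three numbers. The steps were a 1.3-fold lower number from compound 1 to compound 2 (0.11 log units; within the scatter), a 5.9-fold higher number from compound 1 to compound 3 (0.77 log units; beyond the scatter) and a 7.7-fold higher number from compound 2 to compound 3 (0.88 log units; beyond the scatter). Compound 4 `COc1cc(-c2nn(-c3cccc(NC(=O)Nc4ccc(Cl)c(C(F)(F)F)c4)c3)cc2-c2ccncc2)ccc1Cl` carries (4-chloro-3-(trifluoromethyl)phenyl)amino in place of 4-chloro-3-(trifluoromethyl)phenyl on a carbonyl carbon. The same amide-to-urea exchange, combined with a different aryl, appears in the step from compound 1 to compound 2, which stayed within the scatter, while the chloro-bearing aryl of compound 3 sat well above compound 1. A moderate fall is therefore expected, a 2.7-fold lower number from compound 3 to compound 4 (0.43 log units; beyond the scatter), with compound 4 estimated at 7000 nM and a range from 2000 nM to 22000 nM.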

Compound 4, concentration for total growth inhibition: 6290 nM
The estimate for compound 4 lay 1.1-fold (0.05 log units) above the measured number, and the stated range covers the measured number.
By their numbers in this assay, from the lowest: compounds 2, 1 and 4 (each within the scatter of the next, the first and the last beyond it); then compound 3.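

Among the compounds shown here, with the 4-chloro-3-(trifluoromethyl)phenyl group held fixed, changing it to (4-chloro-3-(trifluoromethyl)phenyl)amino on the carbonyl carbon gives a 3.0-fold lower number from compound 3 to compound 4 (0.47 log units; beyond the scatter) in this assay and so isolates the amide-to-urea change for the first time. The aryl still counts among the ureas, since trifluoromethyl in place of chloro gives a 2.6-fold higher number from compound 2 to compound 4 (0.41 log units; beyond the scatter) as a step beyond the scatter, whereas a 2.0-fold higher number from compound 1 to compound 4 (0.30 log units; within the scatter) stays within it, so this urea only regains the level of the amide lacking the chloro. No measurement here explains these shifts. Open, as far as these compounds go, is whether a methyl on the urea nitrogen, or an oxygen in place of that nitrogen as in a carbamate, would keep the gain over the amide. Also open, from the compounds shown here alone, is whether the same exchange helps with an unsubstituted phenyl.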